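This account rests on a few compounds, and the source may have more. Where it says the series, first, only, none or still open, it means among the compounds named here.

Measured so far in an ADME assay on MT4 cells (Homo sapiens) for cytotoxicity, read by MTT assay; on this read-out lower numbers stand for higher toxicity in this test and higher numbers for lower toxicity in this test:
- compound 1 `COc1ccc(CNC(=O)c2[nH]c3ccc(Cl)cc3c2S(=O)(=O)c2cc(C)cc(C)c2)cc1`: 39900 nM
- compound 2 `Cc1cc(C)cc(S(=O)(=O)c2c(C(=O)NCc3cccc(F)c3)[nH]c3ccc(Cl)cc23)c1`: > 53000 nM (a limit)
- compound 3 `Cc1cc(C)cc(S(=O)(=O)c2c(C(=O)NCc3ccc([N+](=O)[O-])cc3)[nH]c3ccc(Cl)cc23)c1`: > 50200 nM (a limit)

Compound 3 has no exact number in this assay: its > 50200 nM is a limit. Compound 2 likewise gives only a limit, > 53000 nM. Compound 1 alone has an exact number, 39900 nM.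

Compound 4 `Cc1cc(C)cc(S(=O)(=O)c2c(C(=O)NCc3ccc(N(C)C)cc3)[nH]c3ccc(Cl)cc23)c1` carries dimethylamino in place of nitro on an aromatic carbon, para to a large group: dimethylamino in place of nitro on an aromatic carbon.

The nearest measured change, nitro in place of methoxy on an aromatic carbon, gave an at least 1.2-fold higher number from compound 1 to compound 3 (0.09 log units; that floor lies within the scatter). The change of the group on the chain carbon gave an at least 1.3-fold higher number from compound 1 to compound 2 (0.12 log units; that floor lies within the scatter). The third change gave a step that the two limits leave unreadable from compound 2 to compound 3. None of these steps shows a size beyond the scatter, so no step beyond the scatter is expected here, in either direction. The expected step is an at least 1.1-fold lower number from compound 3 to compound 4 (0.07 log units; that floor lies within the scatter). Compound 4 is estimated at 42000 nM in this assay. The expected range for compound 4 runs from 18000 nM to 70000 nM, and a limit rather than a number may well be reported.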

Compound 4, half-maximal cytotoxic concentration: 40700 nM
Compound 4: the middle estimate sits 1.0-fold (0.01 log units) above what was measured; low and high end bracket the measured number.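

On the aromatic carbon para to a large group, dimethylamino gives the second exact number in this assay, and exchanging methoxy for it gives a 1.0-fold higher number from compound 1 to compound 4 (0.01 log units; within the scatter). Set against the nitro group and the 3-fluorophenyl group, the same compound gives an at least 1.2-fold lower number from compound 3 to compound 4 (0.09 log units; that floor lies within the scatter) and an at least 1.3-fold lower number from compound 2 to compound 4 (0.11 log units; that floor lies within the scatter), so neither step shows a size beyond the scatter. Compound 3 is known only by a limit: the limit of > 50200 nM in this assay, at which 1 of the 4 values shown sits.

On these data alone, compound 2 is also known only by a limit, so the true size of its step stays open: the limit of > 53000 nM in this assay, at which 1 of the 4 values shown sits. Also open is whether a carboxylic acid or a primary amine at this same place, or a longer chain in place of the benzyl carbon, would move the number beyond the scatter.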